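A few compounds are considered here, and "the series" means these few. Any claim that something is new, unique, unknown or untested is made for them only; others in the source may bear on it.

Compounds measured so far in a functional assay on MCF7 cells (Homo sapiens) for cytotoxicity, read by sulforhodamine B assay, with a stated time of 48 h; on this read-out higher numbers stand for weaker inhibition and lower numbers for stronger inhibition:
compound 1, `O=C1Nc2ccc(Cl)cc2/C1=N/N=C/c1cccs1`, 15300 nM
compound 2, `O=C1Nc2ccc(F)cc2/C1=N/N=C/c1cccs1`, 25800 nM
compound 3, `O=C1Nc2ccc(Cl)cc2/C1=N/N=C/c1ccc[nH]1`, 11800 nM

Compound 1 and compound 2 share a core and differ only in one group: fluoro in place of chloro on an aromatic carbon. That change gave a 1.7-fold higher number from compound 1 to compound 2 (0.23 log units; within the scatter). Compound 3 differs from compound 1 in another place: 1H-pyrrol-2-yl in place of thiophen-2-yl on a carbon with a double bond to nitrogen. That change gave a 1.3-fold lower number from compound 1 to compound 3 (0.11 log units; within the scatter). Compound 3 holds the lowest of the three numbers in this assay, but its nearest neighbour is compound 1 and that gap lies within the scatter, so no order between compound 3 and compound 1 can be claimed; only its gap to compound 2 lies beyond the scatter.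

Compound 4, `O=C1Nc2ccc(F)cc2/C1=N/N=C/c1ccc[nH]1`, has not yet been measured in this assay. It differs from compound 3 in one place: fluoro in place of chloro on an aromatic carbon. The place is the same as in the change from compound 1 to compound 2, so this is the same change made on the core of compound 3. Compound 4 is expected to show a 1.6-fold higher number from compound 3 to compound 4 (0.21 log units; within the scatter), a step of about the size seen earlier, because that earlier change gave a 1.7-fold higher number from compound 1 to compound 2 (0.23 log units; within the scatter). The series is small, and that single step lay within the scatter, so the expectation is held loosely. The estimate for compound 4 in this assay is 19000 nM, with a likely range from 9000 nM to 40000 nM.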

Compound 4, half-maximal inhibitory concentration: 10800 nM
Compound 4: the middle estimate sits 1.8-fold (0.25 log units) above what was measured; low and high end bracket the measured number.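

In this assay, fluoro in place of chloro on the core of compound 3 gave a 1.1-fold lower number from compound 3 to compound 4 (0.04 log units; within the scatter), and this step does not differ from the same change made on the core of compound 1: the same change on two cores in this assay, a 1.7-fold higher number (0.23 log units; within the scatter) from compound 1 to compound 2 and a 1.1-fold lower number (0.04 log units; within the scatter) from compound 3 to compound 4, 1.8-fold (0.27 log units) apart, within the scatter of two such steps. The swap of thiophen-2-yl for 1H-pyrrol-2-yl on the fluoro core gave a 2.4-fold lower number from compound 2 to compound 4 (0.38 log units; beyond the scatter); this step lies beyond the scatter and its counterpart on the chloro core lies within it, yet the two cannot be told apart: the same change on two cores in this assay, a 1.3-fold lower number (0.11 log units; within the scatter) from compound 1 to compound 3 and a 2.4-fold lower number (0.38 log units; beyond the scatter) from compound 2 to compound 4, 1.8-fold (0.27 log units) apart, within the scatter of two such steps. Within these four compounds, then, neither change is seen to behave differently from one core to the other, but each comparison rests on a single pair of small steps, so this does not show that the steps are equal in size or that they would carry over to any further core.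

The compounds shown leave open what other groups would do at the place of chloro, such as bromo, methoxy or a nitrile, and what other rings would do in place of thiophen-2-yl, such as furan-2-yl or phenyl. They also leave open whether a larger step would appear with such groups, and whether it too would carry from one core to the other.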